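The source may hold more compounds than are shown below. What is called first, only, known or untested is meant among the compounds shown, and "the series" means these compounds.

Compound 1 `Nc1nn(Cc2cn(-c3ccc(F)c(Cl)c3)nn2)c2nc(-c3ccccc3)cc(C(F)(F)F)c12` gives 35 ug/mL in a functional assay on HL-60 cells (Homo sapiens) for cytotoxicity, read by MTT assay, with a stated time of 24 h (a lower number here means a stronger inhibitor, a higher number a weaker inhibitor), nominally the lower of the two numbers in hand, though the gap to compound 2 is within the scatter. Compound 2 `Nc1nn(Cc2cn(CC(=O)Nc3cccc(F)c3)nn2)c2nc(-c3ccccc3)cc(C(F)(F)F)c12` gives 63.9 ug/mL in this assay, and a 1.8-fold higher number from compound 1 to compound 2 (0.26 log units; within the scatter). Compound 3 `Nc1nn(Cc2cn(CC(=O)Nc3ccc(F)cc3Br)nn2)c2nc(-c3ccccc3)cc(C(F)(F)F)c12` differs from compound 1 by ((2-bromo-4-fluorophenyl)carbamoyl)methyl in place of 3-chloro-4-fluorophenyl on an aromatic nitrogen. Going by the values given here, the one step that bears on this is the move to a carbamoylmethyl amide on the same nitrogen, which stayed within the scatter, so no step beyond the scatter is expected in this assay. For compound 3 the estimate is 55 ug/mL, with a range from 25 ug/mL to 120 ug/mL. The expected step is a 1.6-fold higher number from compound 1 to compound 3 (0.20 log units; within the scatter).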

Compound 3, half-maximal inhibitory concentration: 63.7 ug/mL
The estimate for compound 3 lay 1.2-fold (0.06 log units) below the measured number, and the stated range covers the measured number.
By their numbers in this assay, from the lowest: compounds 1, 3 and 2 (each within the scatter of the next).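

On the aromatic nitrogen, a second ring pattern on the carbamoylmethyl amide also leaves the number in this assay within the scatter of the directly attached 3-chloro-4-fluorophenyl, with a 1.8-fold higher number from compound 1 to compound 3 (0.26 log units; within the scatter). Within the amide pair, 2-bromo-4-fluorophenyl in place of 3-fluorophenyl on the amide-type nitrogen gives a 1.0-fold lower number from compound 2 to compound 3 (0.00 log units; within the scatter), so this ring change shows no difference here. No measurement at hand offers an explanation for either step.

Still open, from the compounds shown here alone, is whether an amine or a carboxylic acid on that ring would give a step beyond the scatter. The same question stands for a longer chain in place of the carbamoylmethyl link.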